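From 3-Fluorophenyl to 3,5-Dimethylphenyl on a Sulfur

The source may report more compounds than this note shows. Statements on the series, on what has been measured and on what is new or still open speak of the compounds shown alone.

- compound 1 `COc1ccc(SCc2ccc(/C=C/C(=O)Nc3ccccc3N)cc2)cc1OC`: 44.6%
- compound 2 `Nc1ccccc1NC(=O)c1ccc(CSc2cccc(F)c2)cc1`: 83%
- compound 3 `COC(=O)c1ccccc1SCc1ccc(C(=O)Nc2ccccc2N)cc1`: 62.5%

In a functional assay on SMMC-7721 cells (Homo sapiens) for inhibition, read by CCK-8 assay, with a stated time of 72 h, tested at 8 uM (a lower number here means less inhibition of growth, a higher number more inhibition of growth at the concentration tested), compound 2 gives 83%, the highest of the three numbers. Both others lie lower by more than the usual scatter: compound 3 gives 62.5% and compound 1 gives 44.6%.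

The untested compound 4 `Cc1cc(C)cc(SCc2ccc(C(=O)Nc3ccccc3N)cc2)c1` changes one group of compound 2: 3,5-dimethylphenyl in place of 3-fluorophenyl on a sulfur. In words, it carries 3,5-dimethylphenyl in place of 3-fluorophenyl on a sulfur. For the measured compounds named here, no two measured compounds differ in just one place, so the data show no direct size for such a change. Compound 2 shares its core with compound 3, which has another group on the sulfur and gives 62.5%. That single case, together with the top position of compound 2, points to a moderate fall in this assay rather than a rise, though a step within the scatter remains possible. The expected change is a number 17 percentage points lower from compound 2 to compound 4 (beyond the scatter). For compound 4 the estimated value is 66%, with an expected range from 46% to 84%.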

Compound 4, percent growth inhibition at one concentration: 85.1%
Beside the measured number, compound 4's estimate is 19.1 percentage points below it; the measured number lies above the stated range.
By their numbers in this assay, from the lowest: compound 1; then compound 3; then compounds 2 and 4 (each within the scatter of the next).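

Swapping 3-fluorophenyl for 3,5-dimethylphenyl on a sulfur gives, in this assay, a number 2.1 percentage points higher from compound 2 to compound 4 (within the scatter). For the compounds shown here, this is the first direct reading of a single change at this place: the fluorine goes, methyl groups come, and growth inhibition at the tested concentration stays the same within the usual scatter, so in this pair the fluorine is not needed to keep that level. Nothing in the data given here explains this outcome.

The compounds shown leave open whether this place also accepts a phenyl group carrying an amine or a carboxylic acid, or a plain alkyl chain in place of the phenyl group. As far as these compounds go, whether compound 2 and compound 4 would still match at lower concentrations also remains open.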